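The compounds below may be only part of what the source reports. "The series", "measured", "known", "first", "only" and "open" are said of these compounds alone.

Of the compounds shown here, three sharing one core have been measured in a functional assay on Maver1 cells (Homo sapiens) for inhibition, read by luminescence and CellTiter-Glo, with a stated time of 72 h; a lower number here means a stronger inhibitor, a higher number a weaker inhibitor. Compound 1 `C=CC(=O)Nc1ccc(Cn2nc(-c3ccc(Oc4ccccc4)cc3)cc2C(=O)O)cc1` gives only a limit of the assay, > 60000 nM. Compound 2 `O=C(CCl)Nc1ccc(Cn2nc(-c3ccc(Oc4ccccc4)cc3)cc2C(=O)O)cc1` gives 1200 nM. Among the measured compounds shown here, the only measured change of a single group is the step of an at least 50-fold lower number from compound 1 to compound 2 (1.69 log units; beyond the scatter). Compound 3 `C=CC(=O)Nc1cccc(Cn2nc(-c3ccc(Oc4ccccc4)cc3)cc2CO)c1` gives 6700 nM, the highest of the two plain numbers, the closest of which belongs to compound 2. Compound 4 `C=CC(=O)Nc1cccc(Cn2nc(-c3ccc(Oc4ccccc4)cc3)cc2C(=O)O)c1` differs from compound 3 in one place: carboxy in place of hydroxymethyl on an aromatic carbon. For the measured compounds named here, no measured step touches this position, so the step from compound 1 to compound 2 says nothing direct about it; compound 1, which also carries the carboxy group, gave only a limit, while compound 3 with the hydroxymethyl gives a measurable number. On that thin basis compound 4 is expected to come out near compound 3 or somewhat weaker, with an expected step of a 1.5-fold higher number from compound 3 to compound 4 (0.17 log units; within the scatter). The estimate for compound 4 is 10000 nM, with a range from 2000 nM to 60000 nM.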

Compound 4, half-maximal inhibitory concentration: 37400 nM
The estimate for compound 4 lay 3.7-fold (0.57 log units) below the measured number; low and high end bracket the measured number.
By their numbers in this assay, from the lowest: compound 2; then compound 3; then compound 4. At a limit, above all of these: compound 1.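

Among the compounds shown here, with the 3-((vinylcarbonyl)amino)phenyl group held fixed, this is the first measured change on the aromatic carbon next to the ring nitrogen: carboxy in place of hydroxymethyl gives a modest step in this assay, a 5.6-fold higher number from compound 3 to compound 4 (0.75 log units; beyond the scatter). Compounds 2 and 4 both carry the carboxy group, and replacing 4-(((chloromethyl)carbonyl)amino)phenyl with 3-((vinylcarbonyl)amino)phenyl gives a large step, a 31-fold higher number from compound 2 to compound 4 (1.49 log units; beyond the scatter), although that single swapped group differs in both its reactive end and its place on the phenyl ring. Compound 1 stands at a limit: the limit of > 60000 nM in this assay, at which 1 of the 4 values shown sits. Against that limit, the remaining step can be read only as a floor, an at least 1.6-fold lower number from compound 1 to compound 4 (0.20 log units; that floor lies within the scatter).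

The compounds shown leave open whether hydroxymethyl in place of carboxy would change the number by a similar amount alongside the 4-(((chloromethyl)carbonyl)amino)phenyl group of compound 2. They also leave open how a methyl ester or a primary amide would behave on this same aromatic carbon.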